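Anilide to Piperidine Amide on a Shared Nitrobenzofurazan Thioether Chain

This account rests on a few compounds, and the source may have more. Where it says the series, first, only, none or still open, it means among the compounds named here.

Measured compounds:
Compound 1, `O=C(CCC(=O)OCCCCCCSc1ccc([N+](=O)[O-])c2nonc12)Nc1ccccc1Cl`: in an assay on isolated protein for inhibition of glutathione S-transferase Mu 2 (Homo sapiens), with a stated time of 10 min (on this read-out lower numbers stand for stronger inhibition and higher numbers for weaker inhibition), compound 1 gives 330 nM.
Compound 2, `Cc1ccccc1NC(=O)CCC(=O)OCCCCCCSc1ccc([N+](=O)[O-])c2nonc12`: in this assay compound 2 gives 440 nM.
Compound 3, `COc1ccc(NC(=O)CCC(=O)OCCCCCCSc2ccc([N+](=O)[O-])c3nonc23)cc1OC`: in this assay compound 3 gives 360 nM.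

Compound 3 stands second highest of the three numbers, yet all three lie within the scatter of one another: a 1.1-fold higher number from compound 1 to compound 3 (0.04 log units; within the scatter), a 1.2-fold lower number from compound 2 to compound 3 (0.09 log units; within the scatter), and a 1.3-fold higher number from compound 1 to compound 2 (0.12 log units; within the scatter). The three measured compounds differ only in the aryl group on the amide nitrogen, and none of those changes moved the number beyond the scatter.

Compound 4, `O=C(CCC(=O)N1CCCCC1)OCCCCCCSc1ccc([N+](=O)[O-])c2nonc12`, has not been measured. It differs from compound 3 by piperidin-1-yl in place of (3,4-dimethoxyphenyl)amino on a carbonyl carbon. Within the data shown here, no measured step bears directly on this change: every step seen so far exchanged one aryl substituent for another while the anilide itself stayed, whereas here the aromatic ring and the amide hydrogen leave together and a saturated ring enters. The flat response to the aryl changes gives no signal of direction, so a step of modest size at most is expected in this assay, with the uncertainty wide in both directions. Compound 4 is expected to come in at 550 nM, with a range from 180 nM to 1800 nM, meaning an estimated step of a 1.5-fold higher number from compound 3 to compound 4 (0.18 log units; within the scatter).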

Compound 4, half-maximal inhibitory concentration: 110 nM
The estimate for compound 4 lay 5.0-fold (0.70 log units) above the measured number; measured number below the stated range.
By their numbers in this assay, from the lowest: compound 4; then compounds 1, 3 and 2 (each within the scatter of the next).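

In this assay the substituent on the carbonyl carbon turns out to matter after all: swapping one aryl group for another while the anilide stayed left the number within the scatter, whereas piperidin-1-yl in place of the anilide nitrogen and its aryl group gives a 3.3-fold lower number from compound 3 to compound 4 (0.51 log units; beyond the scatter) and, from the other two anilides, a 4.0-fold lower number from compound 2 to compound 4 (0.60 log units; beyond the scatter) and a 3.0-fold lower number from compound 1 to compound 4 (0.48 log units; beyond the scatter) in steps that all lie beyond the scatter. All three steps run in the same direction, none of the anilides goes against it, and compound 4 therefore stands as the strongest inhibitor of the four on this read-out. Nothing shown here gives a measured reason for this gain.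

The change removes the aromatic ring and the amide hydrogen together, so the compounds shown cannot say which of the two departures, or the arrival of the saturated ring itself, carries the effect. A cyclohexylamino group, which keeps the amide hydrogen on a saturated ring, and an N-methylanilino group, which keeps the aromatic ring without that hydrogen, would pull these apart, while morpholin-4-yl or pyrrolidin-1-yl would test how far the piperidine ring can be varied.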